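The source may report more compounds than this note shows. Statements on the series, on what has been measured and on what is new or still open speak of the compounds shown alone.

In a functional assay on MCF7 cells (Homo sapiens) for inhibition, read by MTT assay, with a stated time of 48 h (on this read-out higher numbers stand for weaker inhibition and lower numbers for stronger inhibition), three compounds built on a shared core have been measured. Compound 1 `CCOC(=O)C1=C(N/C=N/c2nnc(S(N)(=O)=O)s2)Nc2[nH]nc(C)c2C1c1ccc(N(C)C)cc1` gives 34500 nM, compound 2 `CCOC(=O)C1=C(N/N=C(\C#N)C(N)=O)Nc2[nH]nc(C)c2C1c1ccc(N(C)C)cc1` gives 50100 nM and compound 3 `CCOC(=O)C1=C(N/C=N/c2ncc(-c3ccccc3)s2)Nc2[nH]nc(C)c2C1c1ccc(N(C)C)cc1` gives 10100 nM. Compound 2 thus stands at the high end of these numbers, level with compound 1, as the data show a 1.5-fold higher number from compound 1 to compound 2 (0.16 log units; within the scatter). Compound 4 `CCOC(=O)C1=C(N/N=C(/Br)c2ccccc2)Nc2[nH]nc(C)c2C1c1ccc(N(C)C)cc1`, not yet measured, departs from compound 2 by a group of 9 heavy atoms (7 carbon, 1 nitrogen, 1 bromine; one six-membered aromatic ring of carbon only) in place of a group of 7 heavy atoms (3 carbon, 3 nitrogen, 1 oxygen; no ring), on an amine nitrogen. For the measured compounds named here, no measured step makes this exact change. The nearest guide is compound 3, which carries a six-membered aromatic ring of carbon only in its changing group and shows a 3.4-fold lower number from compound 1 to compound 3 (0.53 log units; beyond the scatter), a modest step beyond the scatter. The removal of a ring on going to compound 2 gave no step beyond the scatter, so this support is thin. A modest move towards a lower number is therefore expected, and the estimated step is a 2.3-fold lower number from compound 2 to compound 4 (0.36 log units; beyond the scatter). For compound 4 the estimated value is 22000 nM, with an expected range from 8000 nM to 60000 nM.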

Compound 4, half-maximal inhibitory concentration: 78400 nM
Compound 4: middle estimate off by 3.6-fold (0.55 log units), on the low side, outside the stated range (above it).
By their numbers in this assay, from the lowest: compound 3; then compounds 1, 2 and 4 (each within the scatter of the next, the first and the last beyond it).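

In this assay, a six-membered aromatic ring of carbon only in the group on the amine nitrogen does not by itself bring a lower number: replacing the group with no ring gives a 1.6-fold higher number from compound 2 to compound 4 (0.19 log units; within the scatter) and leaves the two groups indistinguishable. Set against the group carrying 5-sulfamoyl-1,3,4-thiadiazol-2-yl, the same entering group gives a 2.3-fold higher number from compound 1 to compound 4 (0.36 log units; beyond the scatter) as the only step shown at this position that rises beyond the scatter. No measurement shown accounts for this result.

The bromine and the phenyl ring enter together, so the compounds shown do not tell which of them matters. Going by these compounds, how a chlorine in place of the bromine, or a carboxylic acid on the phenyl ring, would read also remains open.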